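Anilino variation on a shared enaminone core: cytotoxicity notes

A few compounds are considered here, and "the series" means these few. Any claim that something is new, unique, unknown or untested is made for them only; others in the source may bear on it.

Compound 3, `O=C(/C=C\Nc1cnc2ccccc2c1)c1nc(-c2ccc(C(F)(F)F)cc2)n2ccccc12`, carries a quinolin-3-yl group on the amine nitrogen. In a functional assay on B16-F10 cells (Mus musculus) for cytotoxicity, read by MTT assay, with a stated time of 48 h (a lower number here means a stronger inhibitor, a higher number a weaker inhibitor), compound 3 gives > 30000 nM, which is a limit of the assay and not a number. Its two relatives differ from it only on that nitrogen. Compound 1, `O=C(/C=C\Nc1ccc2cc[nH]c2c1)c1nc(-c2ccc(C(F)(F)F)cc2)n2ccccc12`, bears the 1H-indol-6-yl group; in this assay compound 1 gives > 30000 nM, again a limit. Compound 2, `O=C(/C=C\Nc1ccc(F)cc1)c1nc(-c2ccc(C(F)(F)F)cc2)n2ccccc12`, bears the 4-fluorophenyl group; in this assay compound 2 gives > 30000 nM, also a limit. Accordingly a step that the two limits leave unreadable from compound 1 to compound 2, a step that the two limits leave unreadable from compound 1 to compound 3 and a step that the two limits leave unreadable from compound 2 to compound 3 cannot be sized, owing to the limit of > 30000 nM in this assay, at which 3 of the 3 values shown sit. Compound 4, `COc1ccc(N/C=C\C(=O)c2nc(-c3ccc(C(F)(F)F)cc3)n3ccccc23)cc1`, is the next member of the set: 4-methoxyphenyl in place of quinolin-3-yl on an amine nitrogen. The three unreadable steps leave no measured change on the amine nitrogen to build on, and no readable value for compound 4 is expected. Compound 4 is expected to give 40000 nM, with a range of 12000 nM to 150000 nM, most probably reported once more as a limit. The step that the limit leaves unreadable from compound 3 to compound 4 is the estimated outcome, expected to be none beyond the scatter.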

Compound 4, half-maximal inhibitory concentration: > 30000 nM
Compound 4: a limit, no number; the forecaster's own chance of this, stated with the estimate: 85%; the middle value lies beyond the limit too.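

In this assay no new step can be read among compound 1, compound 2, compound 3 and compound 4, because each gives only a limit: the limit of > 30000 nM in this assay, at which 4 of the 4 values shown sit. The compounds shown leave open whether any group on the amine nitrogen of the shared core gives a readable value in this assay at all.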